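A few compounds are considered here, and "the series" means these few. Any claim that something is new, unique, unknown or untested is made for them only; others in the source may bear on it.

Measured so far: compound 1 `OCCCc1cn[nH]c1` with 560 nM; compound 2 `ClCCCc1cc[nH]n1` with 40000 nM; compound 3 `OCCCc1cc[nH]n1` with 60000 nM.

In an assay for inhibition of alcohol dehydrogenase (Equus caballus), read by spectrophotometry, in the presence of a further agent that is not named here (on this read-out higher numbers stand for weaker binding and lower numbers for tighter binding), compound 1 gives the lowest of the three numbers, and its gap to compound 2 and to compound 3 lies well beyond the scatter. Among the measured compounds shown here, the one measured step, a 1.5-fold higher number from compound 2 to compound 3 (0.18 log units; within the scatter), concerns a different change on the shared core and is within the scatter. Compound 4 `OCc1cn[nH]c1` differs from compound 1 by hydroxy in place of 2-hydroxyethyl on a saturated chain carbon bound to an aromatic carbon. For the measured compounds named here, no measured step bears on this change, so no direction can be drawn from the numbers. Compound 4 is therefore expected to stay close to compound 1, with a 1.8-fold higher number from compound 1 to compound 4 (0.25 log units; within the scatter) as a step within the scatter. The estimate for compound 4 is 1000 nM, in the range 200 nM to 5000 nM.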

Compound 4, dissociation constant: 3600 nM
For compound 4 the middle estimate is 3.6-fold (0.56 log units) below the measured one; the measured number falls inside the stated range.
By their numbers in this assay, from the lowest: compound 1; then compound 4; then compounds 2 and 3 (each within the scatter of the next).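

In this assay, the chain on the shared core does register: hydroxy in place of 2-hydroxyethyl on a saturated chain carbon bound to an aromatic carbon gives a modest change (a 6.4-fold higher number from compound 1 to compound 4 (0.81 log units; beyond the scatter)). Among the compounds shown here, this is the first measured step at this position, and unlike the one earlier step, it lies beyond the scatter. No evidence at hand accounts for its size.

Going by these compounds, whether a longer chain, or an amine in place of the hydroxy, would keep or lose the number of compound 1 stays open. So does whether the same change would have a similar effect on compound 3.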